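Oxetane to Oxane: A Solubility Step Still Unmeasured

The source may report more compounds than this note shows. Statements on the series, on what has been measured and on what is new or still open speak of the compounds shown alone.

Within the data shown here, compound 1 `Nc1nccc(-c2cc(OC3COC3)c3c(N)n[nH]c3c2)n1` gives 383000 nM in a physicochemical assay for solubility, read by LC-MS, in phosphate buffer, measured as kinetic solubility, with a stated time of 24 h, at 25 degrees C, at pH 7.4 (a lower number here means a less soluble compound, a higher number a more soluble compound), the top of three numbers so far. Compound 2 `Nc1nccc(-c2ccc3cn[nH]c3c2)n1` gives 215000 nM in this assay, which lies within the scatter of compound 1, while compound 3 `Nc1nccc(-c2cc3c4c(n[nH]c4c2)Nc2ccncc2O3)n1` gives 10000 nM, far beyond it. Compound 4 `Nc1nccc(-c2cc(OC3CCOCC3)c3c(N)n[nH]c3c2)n1` differs from compound 1 only by oxan-4-yl in place of oxetan-3-yl on an oxygen on an aromatic ring. Among the measured compounds shown here, no measured pair shows this change, so its size is unknown from the data. For compound 4 the expected step is a 2.1-fold lower number from compound 1 to compound 4 (0.33 log units; beyond the scatter), a small drop that may not exceed the scatter. Compound 4 is therefore estimated at 180000 nM in this assay, with a range from 60000 nM to 400000 nM.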

Compound 4, solubility: 770000 nM
Estimate against measurement, compound 4: 4.3-fold (0.63 log units) below; the measured number lies above the stated range.
By their numbers in this assay, from the lowest: compound 3; then compounds 2, 1 and 4 (each within the scatter of the next, the first and the last beyond it).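

In this assay, oxan-4-yl in place of oxetan-3-yl on an oxygen on an aromatic ring gives a 2.0-fold higher number from compound 1 to compound 4 (0.30 log units; within the scatter), so this only measured pair at this place does not separate the six-membered ring from the four-membered ring. No evidence given here bears on this result. Going by these compounds, it remains open whether an amine such as piperidin-4-yl, a carboxylic acid or a longer chain on this oxygen would stay within the scatter of compound 1, and whether the same change would read alike on another core.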